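This account rests on a few compounds, and the source may have more. Where it says the series, first, only, none or still open, it means among the compounds named here.

Measured compounds in a functional assay on MX1 cells (Homo sapiens) for inhibition, read by MTT assay, with a stated time of 120 h; on this read-out lower numbers stand for stronger inhibition and higher numbers for weaker inhibition:

- compound 1, `CC1CN(C(=O)c2ccc(-c3ccc(NC(=O)Nc4ccc(Cl)c(C(F)(F)F)c4)cc3)cc2)CC(C)O1`, gives > 50000 nM, a limit of the assay and not a number.
- compound 2, `CNC(=O)/C=C/c1ccc(NC(=O)Nc2ccc(Cl)c(C(F)(F)F)c2)cc1`, gives 13800 nM.
- compound 3, `C/C(=C\C(=O)N1CC(C)OC(C)C1)c1ccc(NC(=O)Nc2ccc(Cl)c(C(F)(F)F)c2)cc1`, gives > 50000 nM, again a limit of the assay.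

Where compound 1 stands: on this assay it shows no number at all, only the limit, and it shares that position with compound 3, as the limit of > 50000 nM in this assay, at which 2 of the 3 values shown sit, records. Among the compounds with values here, compound 2 is the only member of the set with a measured value. Within the data shown here, no pair of measured compounds differs in a single place, so no measured step can be drawn from these three.

Compound 4, `CC1CN(C(=O)c2ccc(-c3ccc(NC(=O)Nc4cc(C(F)(F)F)ccc4Cl)cc3)cc2)CC(C)O1`, is the next compound for this assay. Its difference from compound 1 is 2-chloro-5-(trifluoromethyl)phenyl in place of 4-chloro-3-(trifluoromethyl)phenyl on an amide-type nitrogen; the two have the same atoms, joined differently, and the urea, the biaryl and the cyclic amide of the shared core are untouched.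

Expected size of the step: with compound 1 at the limit and with the limit of > 50000 nM in this assay, at which 2 of the 3 values shown sit, showing two of three values sitting there, no step beyond the scatter toward a measurable value is expected, and compound 4 is expected to remain at or near the limit. The estimate for compound 4 is 60000 nM (range 20000 nM to 200000 nM), which means an expected step that the limit leaves unreadable from compound 1 to compound 4.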

Compound 4, half-maximal inhibitory concentration: > 50000 nM
Compound 4: only a limit was reported (the forecaster's own chance of this, stated with the estimate: 80%); the middle value does not contradict the limit.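

Compound 4, like compound 1, shows only a limit of the assay in this assay, so no step can be read between them. The compounds shown leave open whether 2-chloro-5-(trifluoromethyl)phenyl and 4-chloro-3-(trifluoromethyl)phenyl differ at all on the shared core, because most of the set sits at one value: the limit of > 50000 nM in this assay, at which 3 of the 4 values shown sit.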